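The compounds below may be only part of what the source reports. "The series", "measured", "known", "first", "only" and "open" are said of these compounds alone.

Measured so far in an ADME assay on BHK-21 cells (Mesocricetus auratus) for cytotoxicity, read by MTT assay, with a stated time of 72 h; on this read-out lower numbers stand for higher toxicity in this test and higher numbers for lower toxicity in this test:

- compound 1 `Cc1ccccc1C1CC(c2ccc(OCc3ccccc3)cc2)=NN1c1ccc(S(N)(=O)=O)cc1`: 20000 nM
- compound 2 `NS(=O)(=O)c1ccc(N2N=C(c3ccc(Oc4ccccc4)cc3)CC2c2cccc(F)c2)cc1`: 10000 nM

In this assay, compound 1 gives 20000 nM and compound 2 gives 10000 nM. These two values lie within the usual scatter of each other, so compound 2 cannot be separated from compound 1 on these numbers. Among the measured compounds shown here, the two compounds differ in more than one place, and no measured pair differs in one place only. No direct measure of a single change is therefore available.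

Compound 3 `NS(=O)(=O)c1ccc(N2N=C(c3ccc(Oc4ccccc4)cc3)CC2c2ccc(F)cc2)cc1` is the next to be read. It carries 4-fluorophenyl in place of 3-fluorophenyl on a saturated ring carbon. The two compounds have the same atoms, joined differently.

The closest reference is compound 2 at 10000 nM, and compound 1 at 20000 nM does not lie beyond the scatter from it despite its larger differences. No step beyond the scatter is expected in this assay, and neither direction is favoured. The estimated 1.2-fold higher number from compound 2 to compound 3 (0.08 log units; within the scatter) is expected to stay within the scatter. For compound 3 the expected value is 12000 nM, with an estimated range of 5000 nM to 25000 nM.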

Compound 3, half-maximal cytotoxic concentration: 8000 nM
Estimate against measurement, compound 3: 1.5-fold (0.18 log units) above; the measured number falls inside the stated range.
By their numbers in this assay, from the lowest: compounds 3, 2 and 1 (each within the scatter of the next, the first and the last beyond it).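

Among the compounds shown here, the first comparison that differs in one place only comes from this assay: 4-fluorophenyl in place of 3-fluorophenyl on a saturated ring carbon gives a 1.3-fold lower number from compound 2 to compound 3 (0.10 log units; within the scatter). On this pair, with the rest of the structure held constant, the two fluorophenyl isomers cannot be told apart in this test, so moving the fluorine from the 3-position to the 4-position of this phenyl group leaves no readable mark on the half-maximal cytotoxic concentration. Nothing in the available data explains this result or links it to any property of the two groups.

For the compounds shown here, the reading covers only one isomer swap at this ring carbon, so it remains open whether 2-fluorophenyl, 4-chlorophenyl, a pyridyl ring or a phenyl group carrying an amine or a carboxylic acid would give a step beyond the scatter. As far as these compounds go, it is also open whether the same swap would read alike with the benzyloxy group of compound 1 in the structure, since that group and the 2-methylphenyl group of compound 1 have no single-place comparison of their own.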